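The source may hold more compounds than are shown below. What is called first, only, known or untested is meant among the compounds shown, and "the series" means these compounds.

Going by the values given here, compound 1 `COc1cc(NC(C)CCCN2C(=O)CN(C(=O)[C@H](N)CCSC)C2(C)C)c2ncccc2c1` is the less lipophilic of the two measured members: in a physicochemical assay for lipophilicity, measured as octanol-water partition (on this read-out lower numbers stand for lower lipophilicity and higher numbers for higher lipophilicity), compound 1 gives 2.94, and compound 2 `COc1cc(NC(C)CCCN2C(=O)[C@@H](C)NC2(C)C)c2ncccc2c1` gives 3.25, a gap beyond the scatter. Compound 3 `COc1cc(NC(C)CCCN2C(=O)CN(C(=O)CN)C2(C)C)c2ncccc2c1` has not yet been run in this assay. Relative to compound 1 it carries hydrogen in place of 2-(methylsulfanyl)ethyl on a saturated chain carbon bound to an amine nitrogen and a carbonyl carbon. Among the compounds with values here, no measured pair shows this change, so the expected step rests on the loss of the group alone: a fall well beyond the scatter, estimated as a number 1.04 log units lower from compound 1 to compound 3 (beyond the scatter). Compound 3 is therefore expected to give about 1.9, somewhere between 1.3 and 2.5.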

Compound 3, partition coefficient: 2.19
Estimate against measurement, compound 3: 0.29 log units below; measured number inside the range.
By their numbers in this assay, from the lowest: compound 3; then compound 1; then compound 2.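

Going by these compounds alone, replacing 2-(methylsulfanyl)ethyl with hydrogen on the saturated chain carbon bound to an amine nitrogen and a carbonyl carbon gives the only measured step at this position in this assay, a number 0.75 log units lower from compound 1 to compound 3 (beyond the scatter), and it lies beyond the scatter. The read-out at this position therefore responds to the removal of this group, and compound 3 stands lowest of the three. No evidence bears on the origin of this step.

On these data alone, with a single change at this position, the separate contributions of chain length and sulfur remain open. A methyl or a butyl group on the same carbon would help to separate them.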